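Diamine series: cell toxicity before the next measurement

The source may hold more compounds than are shown below. What is called first, only, known or untested is meant among the compounds shown, and "the series" means these compounds.

Among the compounds with values here, the series so far holds compound 1 `Nc1cc(N)c2nc(-c3ccccc3)c(Oc3ccc(Cl)c(Cl)c3)nc2c1`, compound 2 `CCOC(=O)[C@H](CCC(=O)O)NC(=O)c1ccc(Sc2nc3cc(N)cc(N)c3nc2-c2ccccc2)cc1` and compound 3 `CCOC(=O)[C@H](CCC(=O)O)NC(=O)c1ccc(Oc2nc3cc(N)cc(N)c3nc2-c2ccccc2)cc1`, all run in a functional assay on OVCAR-8 cells (Homo sapiens) for inhibition, read by sulforhodamine B assay, with a stated time of 48 h; on this read-out higher numbers stand for lower toxicity in this test and lower numbers for higher toxicity in this test. For compound 1 the result is only a limit, < 100000 nM. Compound 2 likewise gives only a limit, < 100000 nM. Compound 3 also stops at a limit, < 100000 nM. Where compound 1 stands among the others therefore cannot be told, since the limit of < 100000 nM in this assay, at which 3 of the 3 values shown sit, and no ordering follows. Compound 4 `Nc1cc(N)c2nc(-c3ccccc3)c(NCc3ccc(F)cc3)nc2c1` is not yet measured; it differs from compound 1 by (4-fluorobenzyl)amino in place of 3,4-dichlorophenoxy on an aromatic carbon. Within the data shown here, no step between measured compounds exists, so no direction beyond the usual scatter is expected. For compound 4 the expected result is 30000 nM, between 5000 nM and 100000 nM, most likely again a limit. The step this estimate means is a step that the limit leaves unreadable from compound 1 to compound 4.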

Compound 4, concentration lethal to 50% of the cells: 21900 nM
For compound 4 the middle estimate is 1.4-fold (0.14 log units) above the measured one; the measured number falls inside the stated range.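

The step from compound 1 to compound 4 cannot be read, because compound 1 gives only a limit: the limit of < 100000 nM in this assay, at which 3 of the 4 values shown sit. The compounds shown leave open how (4-fluorobenzyl)amino and 3,4-dichlorophenoxy compare on the shared core.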